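The compounds below may be only part of what the source reports. "The series", "measured", "known", "first", "only" and "open" are said of these compounds alone.

Series notes.

The series shares a peptide-like core in which the amide-bound substituent on the carbonyl carbon is varied. Compound 1 `CCOC(=O)/C=C/[C@H](CC(C)C)NC(=O)[C@H](CO)NC(=O)[C@@H](NC(=O)OCc1ccccc1)C(C)C` carries a benzyloxy group on that carbonyl. In an ADME assay on a cell-free system (plasma, Homo sapiens) for metabolic stability (a lower number here means that the compound disappears faster, a higher number that the compound lasts longer), compound 1 gives 3.97 h. Compound 2 `CCOC(=O)/C=C/[C@H](CC(C)C)NC(=O)[C@H](CO)NC(=O)[C@@H](NC(=O)C1=CCCNC1)C(C)C` carries a six-membered non-aromatic ring with one nitrogen in place of the benzyloxy group. In this assay compound 2 reaches only the limit > 6 h, a bound of the method rather than a number. The step of an at least 1.5-fold higher number from compound 1 to compound 2 (0.17 log units; that floor lies within the scatter) thus rests on the fact that (the limit of > 6 h in this assay, at which 1 of the 2 values shown sits).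

Compound 3 `CCOC(=O)/C=C/[C@H](CC(C)C)NC(=O)[C@H](CO)NC(=O)[C@@H](NC(=O)c1cccc(O)c1C)C(C)C` is the next member. Relative to compound 2 the change is a group of 8 heavy atoms (7 carbon, 1 oxygen; one six-membered aromatic ring of carbon only) in place of a group of 6 heavy atoms (5 carbon, 1 nitrogen; one six-membered non-aromatic ring with 1 hetero atom), on a carbonyl carbon. Among the compounds with values here, the only measured step, from compound 1 to compound 2, went in the opposite structural sense, non-aromatic ring in for aromatic ring, and its floor lies within the scatter, so it carries little weight for the present direction.

The expectation for compound 3 in this assay is therefore a modest drop, an at least 1.2-fold lower number from compound 2 to compound 3 (0.07 log units; that floor lies within the scatter), back toward the region of compound 1. The estimated half-life for compound 3 is 5 h, within 2.5 h to 10 h.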

Compound 3, half-life: > 6 h
Compound 3: a limit, no number; the forecaster's own chance of this, stated with the estimate: 40%; at least 1.2-fold (0.07 log units) between middle value and limit.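

In this assay compound 3 gives > 6 h, which is a limit of the method and not a number. Within the data shown here, on the carbonyl carbon, 3-hydroxy-2-methylphenyl in place of benzyloxy gives an at least 1.5-fold higher number from compound 1 to compound 3 (0.17 log units; that floor lies within the scatter), so an aromatic ring of carbon only at this place is compatible with a read-out at the limit, and the non-aromatic ring of compound 2 is not the only group that reaches it, although this floor is too small to establish a real gain. The step that joins the two limits cannot be read, and the series offers little resolution at this end of the range: the limit of > 6 h in this assay, at which 2 of the 3 values shown sit.

Going by these compounds, how far compound 2 and compound 3 lie past the limit remains open, so the non-aromatic ring with one nitrogen and 3-hydroxy-2-methylphenyl cannot be ordered against each other. Also open, on these data alone, is whether a primary amine, a carboxylic acid or a longer alkyl chain at this place on the carbonyl carbon would give a half-life that can be read as a number in this assay.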